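The source may report more compounds than this note shows. Statements on the series, on what has been measured and on what is new or still open speak of the compounds shown alone.

Compound 2, `CC[C@H]1OC(=O)[C@H](C)C(=O)[C@H](C)[C@@H](O[C@@H]2O[C@H](C)C[C@H](N(C)Cc3ccc(-c4cn(CC(=O)NO)nn4)cc3)[C@H]2O)[C@@](C)(OC)C[C@@H](C)C2=NCCN3C(=O)O[C@@]1(C)[C@H]3[C@H]2C`, gives 2850 nM in an assay for inhibition of histone deacetylase 8 (Homo sapiens), read by mass spectrometry, with a stated time of 60 min; a higher number here means a weaker inhibitor, a lower number a stronger inhibitor. Compound 1, `CC[C@H]1OC(=O)[C@H](C)C(=O)[C@H](C)[C@@H](O[C@@H]2O[C@H](C)C[C@H](N(C)Cc3cccc(-c4cn(CCCCCC(=O)NO)nn4)c3)[C@H]2O)[C@@](C)(OC)C[C@@H](C)C2=NCCN3C(=O)O[C@@]1(C)[C@H]3[C@H]2C`, gives 3230 nM in this assay; the two numbers lie within the scatter of each other, so no order between them is claimed. Compound 3, `CC[C@H]1OC(=O)[C@H](C)C(=O)[C@H](C)[C@@H](O[C@@H]2O[C@H](C)C[C@H](N(C)Cc3ccc(-c4cn(CCCCC(=O)NO)nn4)cc3)[C@H]2O)[C@@](C)(OC)C[C@@H](C)C2=NCCN3C(=O)O[C@@]1(C)[C@H]3[C@H]2C`, carries 3-(hydroxycarbamoyl)propyl in place of hydroxycarbamoyl on a saturated chain carbon bound to an aromatic nitrogen. Going by the values given here, no step between measured compounds isolates this change; compound 1, with its longer chain, gives 3230 nM, which offers no sign of a shift. The step from compound 2 to compound 3 is therefore expected to stay within the scatter, at a 1.1-fold higher number from compound 2 to compound 3 (0.02 log units; within the scatter). Compound 3 is estimated at 3000 nM, within 1200 nM to 7500 nM.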

Compound 3, half-maximal inhibitory concentration: 3210 nM
The estimate for compound 3 lay 1.1-fold (0.03 log units) below the measured number; the range from low to high includes it.
By their numbers in this assay, from the lowest: compounds 2, 3 and 1 (each within the scatter of the next).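

In this assay, going by these compounds alone, 3-(hydroxycarbamoyl)propyl in place of hydroxycarbamoyl on a saturated chain carbon bound to an aromatic nitrogen gives a 1.1-fold higher number from compound 2 to compound 3 (0.05 log units; within the scatter), the first direct reading of this change. With only the chain altered, lengthening it leaves the number within the scatter. No measurement at hand accounts for this result.

On these data alone, whether a carboxylic acid or a primary amide in place of the hydroxycarbamoyl would shift the number remains open. As far as these compounds go, a chain longer than 4-(hydroxycarbamoyl)butyl on the same core also remains open.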